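Aryl enone boronic acids: cytotoxicity on fibroblasts

The source may report more compounds than this note shows. Statements on the series, on what has been measured and on what is new or still open speak of the compounds shown alone.

Measured compounds:
compound 1, `O=C(/C=C/c1ccc2c(c1)B(O)OC2)c1ccc(-c2ccccc2)cc1`, 18300 nM
compound 2, `Cn1cccc1C(=O)/C=C/c1ccc2c(c1)B(O)OC2`, > 100000 nM
compound 3, `CCOC(=O)c1ccc(C(=O)/C=C/c2ccc3c(c2)B(O)OC3)cc1`, 47200 nM

The three compounds share one core and differ only in the aryl group attached to the carbonyl carbon. In a toxicity assay on WI-38 cells (Homo sapiens) for cytotoxicity, read by MTT assay, with a stated time of 48 h (a lower number here means a stronger inhibitor, a higher number a weaker inhibitor), compound 1 gives 18300 nM. Among the compounds with values here, compound 3 gives 47200 nM in this assay, and the one measured step, a 2.6-fold higher number from compound 1 to compound 3 (0.41 log units; beyond the scatter), is a modest move toward weaker inhibition. Compound 2 sits apart: its value in this assay is a limit, (the limit of > 100000 nM in this assay, at which 1 of the 3 values shown sits), so no number places it against the other two.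

The unmeasured compound 4, `O=C(/C=C/c1ccc2c(c1)B(O)OC2)c1cccc(F)c1`, differs from compound 2 by 3-fluorophenyl in place of 1-methyl-1H-pyrrol-2-yl on a carbonyl carbon. Within the data shown here, no measured step covers this exchange; the only guide is that the two phenyl-bearing compounds 1 and 3 both give numbers within this assay. Compound 4 is therefore expected to land in the same region, roughly between those two, with a real chance that it too reaches the limit.

The estimated step from compound 2 to compound 4 is an at least 1.6-fold lower number from compound 2 to compound 4 (0.22 log units; that floor lies within the scatter), an expected move toward a measurable number. Compound 4 is expected to give about 60000 nM in this assay, within 25000 nM to 150000 nM.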

Compound 4, half-maximal inhibitory concentration: 26700 nM
Compound 4: middle estimate off by 2.2-fold (0.35 log units), on the high side, and the stated range covers the measured number.
By their numbers in this assay, from the lowest: compounds 1, 4 and 3 (each within the scatter of the next, the first and the last beyond it). At a limit, above all of these: compound 2.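

In this assay, 3-fluorophenyl in place of 1-methyl-1H-pyrrol-2-yl on the carbonyl carbon gives an at least 3.7-fold lower number from compound 2 to compound 4 (0.57 log units; beyond the scatter), the first listed step that starts from compound 2 and so the first to connect it with the compounds that have numbers. At 26700 nM, compound 4 lies within the scatter of both compound 1 and compound 3, so this position has now taken three different aryl groups with numbers that span only a modest range, while the pyrrole-bearing compound stands apart from them. The true size of the step remains unknown, and the printed figure is only a floor, since the value of compound 2 is a limit and not a number: the limit of > 100000 nM in this assay, at which 1 of the 4 values shown sits.

The compounds shown leave open whether the gap belongs to 1-methyl-1H-pyrrol-2-yl in particular or would extend to other five-membered aromatic rings on this carbon, such as a thiophene or a furan. They also leave open how this assay would read with an amine or a carboxylic acid in place of the fluorine of compound 4.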